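Thiophen-2-yl in place of pyridin-2-yl: working notes

The compounds below may be only part of what the source reports. "The series", "measured", "known", "first", "only" and "open" are said of these compounds alone.

In a physicochemical assay, with a stated time of 30 min (on this read-out lower numbers stand for an effect already at smaller amounts and higher numbers for an effect only at larger amounts of compound), compound 1 (`C/C(=N/N=C1\SCC(=O)N1Cc1ccc(F)cc1)c1ccccn1`) gives 1750000 nM and compound 2 (`C/C(=N\N=C1/SCC(=O)N1Cc1cccc(Cl)c1)c1ccccn1`) gives 1400000 nM and these two numbers lie within the scatter of each other. Compound 3 (`C/C(=N/N=C1\SCC(=O)N1Cc1ccc(F)cc1)c1cccs1`) carries thiophen-2-yl in place of pyridin-2-yl on a carbon with a double bond to nitrogen. Within the data shown here, no measured pair shows this change or any other single change. In this assay no step beyond the scatter is expected, and no direction is favoured. The expected step (a 1.2-fold lower number from compound 1 to compound 3 (0.07 log units; within the scatter)) is correspondingly small. Compound 3 is estimated at 1500000 nM (range 700000 nM to 3200000 nM).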

Compound 3, half-maximal effective concentration: 1850000 nM
Estimate against measurement, compound 3: 1.2-fold (0.09 log units) below; low and high end bracket the measured number.
By their numbers in this assay, from the lowest: compounds 2, 1 and 3 (each within the scatter of the next).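

In this assay, among these compounds, thiophen-2-yl in place of pyridin-2-yl on a carbon with a double bond to nitrogen gives a 1.1-fold higher number from compound 1 to compound 3 (0.02 log units; within the scatter), the only single-change step so far. At this place, a five-membered aromatic ring with sulfur and a six-membered aromatic ring with nitrogen therefore read alike. No measurement bears on why the two rings read alike. The compounds shown hold only these two aromatic rings at this place, so the effect of an amine or a carboxylic acid there remains open.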